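A few compounds are considered here, and "the series" means these few. Any claim that something is new, unique, unknown or untested is made for them only; others in the source may bear on it.

Notes on the series. Compound 1 `CC(=O)Oc1ccc2c(c1)C(n1ccccc1=O)=CC(C)(C)O2` and compound 2 `CC1(C)C=C(n2ccccc2=O)c2cc(OS(=O)(=O)F)ccc2O1` share one core and differ only in the group on the aromatic oxygen. In a functional assay (aorta) with Rattus norvegicus as the target (a lower number here means a less potent compound, a higher number a more potent compound, by a factor of ten per unit of this negative logarithm), compound 1 gives 5.6, while compound 2 gives 7.95. Among the compounds with values here, the single measured step, a number 2.35 log units higher from compound 1 to compound 2 (beyond the scatter), is the only comparison available; compound 2 therefore stands highest of the two numbers, with compound 1 as the nearest neighbour and well beyond the scatter below it.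

Compound 3 `CC1(C)C=C(n2ccccc2=O)c2cc(C#N)ccc2O1` carries the change (cyano in place of (fluorosulfonyl)oxy on an aromatic carbon). Within the data shown here, no measured step replaces the group on that aromatic carbon with a cyano, so nothing bears directly on this step; the one step seen, from acetyl to fluorosulfonyl on the oxygen, only shows that this position tolerates large swings in this assay. The expectation for compound 3 is a moderate drop from compound 2, a number 0.45 log units lower from compound 2 to compound 3 (beyond the scatter), with wide uncertainty in both directions. In this assay compound 3 is estimated at 7.5, within a range from 6.3 to 8.6.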

Compound 3, logarithm of the reciprocal of the active concentration, log(1/C): 7.67
Compound 3: the middle estimate sits 0.17 log units below what was measured, within the range that was stated.
By their numbers in this assay, from the lowest: compound 1; then compounds 3 and 2 (each within the scatter of the next).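

Working from the new value, this assay places the two groups close together: a number 0.28 log units lower from compound 2 to compound 3 (within the scatter), so cyano and (fluorosulfonyl)oxy on this aromatic carbon cannot be told apart on this read-out, even though the count of heavy atoms leaving and entering differs and only one of the two groups is joined through an oxygen. The acetoxy group stays well separated from cyano, with a number 2.07 log units higher from compound 1 to compound 3 (beyond the scatter), and this second large step shows that a high number at this position does not require the (fluorosulfonyl)oxy group, so the large gap seen so far belongs to acetoxy set against either of the other two groups. No accompanying measurement on these compounds accounts for either step.

From the compounds shown here alone, whether an amine, a carboxylic acid or a longer chain such as methoxyethyl on the same aromatic carbon would keep a number in the range of compound 2 and compound 3 or fall towards compound 1 remains open. Also open, going by these compounds, is where a bare hydrogen or a single chlorine atom at this position would stand relative to these three groups.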